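The source may report more compounds than this note shows. Statements on the series, on what has been measured and on what is new or still open speak of the compounds shown alone.

Of the compounds shown here, two sharing one core have so far been measured in a functional assay on MCF7 cells (Homo sapiens) for inhibition, read by sulforhodamine B assay, with a stated time of 72 h; on this read-out higher numbers stand for weaker inhibition and lower numbers for stronger inhibition. Compound 1 `O=C(/C=C/c1cn(-c2ccccc2)nc1-c1cccnc1)c1ccsc1` gives 500 nM in this assay. Compound 2 `O=C(/C=C/c1cn(-c2ccccc2)nc1-c1ccncc1)c1ccsc1` gives 1500 nM in this assay. Within the data shown here, the single step separating them, a 3.0-fold higher number from compound 1 to compound 2 (0.48 log units; beyond the scatter), puts pyridin-4-yl in place of pyridin-3-yl on an aromatic carbon. Among the measured compounds shown here, compound 2 therefore holds the higher of the two numbers measured so far, and its gap to compound 1 lies beyond the scatter.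

Compound 3 `COc1ccc(C(=O)/C=C/c2cn(-c3ccccc3)nc2-c2ccncc2)cc1OC` has not yet been measured. It differs from compound 2 at a different place: 3,4-dimethoxyphenyl in place of thiophen-3-yl on a carbonyl carbon. For the measured compounds named here, no measured step touches the group on the carbonyl carbon; the only step known, from compound 1 to compound 2, concerns the pyridyl ring and gives no guidance on what an exchange at the carbonyl carbon does to the number. With no guide, the expectation for compound 3 is a number near that of compound 2, with a broad range in either direction. The estimated change is no change at the digits printed from compound 2 to compound 3 (within the scatter). Compound 3 is expected to give about 1500 nM in this assay, within a range from 400 nM to 6000 nM.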

Compound 3, half-maximal inhibitory concentration: 4300 nM
For compound 3 the middle estimate is 2.9-fold (0.46 log units) below the measured one; measured number inside the range.
By their numbers in this assay, from the lowest: compound 1; then compound 2; then compound 3.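

The group on the carbonyl carbon also moves the number in this assay: putting 3,4-dimethoxyphenyl in place of thiophen-3-yl gives a 2.9-fold higher number from compound 2 to compound 3 (0.46 log units; beyond the scatter), a shift towards weaker inhibition at a position the earlier step at the pyridyl ring did not touch. The exchange is large in structural terms, since a five-membered aromatic ring with one hetero atom gives way to a six-membered aromatic ring of carbon only, yet the step is only modest and this position tolerates both groups with a measurable number. No supporting measurement bears on why the number rose.

The compounds shown leave open whether the change of ring or the methoxy groups matter more, a question that a plain phenyl group on the carbonyl carbon could help settle. They also leave open whether the step would hold with pyridin-3-yl, the ring found in compound 1, in place of pyridin-4-yl, and what an amine on the ring at the carbonyl carbon would do.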